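The source may report more compounds than this note shows. Statements on the series, on what has been measured and on what is new or still open speak of the compounds shown alone.

Compounds measured in a functional assay on U-87MG ATCC cells (Homo sapiens) for cytotoxicity, read by MTT assay, with a stated time of 72 h (a lower number here means a stronger inhibitor, a higher number a weaker inhibitor), so far:

Compound 1 `COc1ccc(/C=N/NC(=O)Nc2ccc(Oc3ccnc(-c4nncn4CCN(C)C)c3)c(F)c2)c(OC)c1` gives 12600 nM in this assay.
Compound 2 `CN(C)CCn1cnnc1-c1cc(Oc2ccc(NC(=O)N/N=C/c3ccc(F)cc3F)cc2F)ccn1` gives 1900 nM in this assay.
Compound 3 `CN(C)CCn1cnnc1-c1cc(Oc2ccc(NC(=O)N/N=C/c3ccc(Cl)cc3)cc2F)ccn1` gives 1370 nM in this assay.

Compound 3 carries the lowest of the three numbers. Its nearest neighbour is compound 2, and the step of a 1.4-fold lower number from compound 2 to compound 3 (0.14 log units; within the scatter) lies within the scatter, so the two cannot be ordered. Against compound 1 the gap is clear: a 9.2-fold lower number from compound 1 to compound 3 (0.96 log units; beyond the scatter), and likewise a 6.6-fold lower number from compound 1 to compound 2 (0.82 log units; beyond the scatter). The only substantial movement in the series therefore comes from replacing the 2,4-dimethoxyphenyl group on the carbon double-bonded to nitrogen by a halogenated phenyl group.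

Compound 4 `CN(C)CCn1cnnc1-c1cc(Oc2ccc(NC(=O)N/N=C/c3ccc(O)cc3)cc2F)ccn1` is not yet measured. It differs from compound 3 by hydroxy in place of chloro on an aromatic carbon. Among the measured compounds shown here, none of the measured steps covers a hydroxy group at this position; the two steps from compound 1 show that a change of the substituent on this phenyl ring can move the number by a modest amount, while the step from compound 2 to compound 3 shows that two different small substituents can leave it within the scatter. The expectation for compound 4 is a step of a 2.0-fold higher number from compound 3 to compound 4 (0.31 log units; beyond the scatter), towards a somewhat higher number, of uncertain size. Compound 4 is estimated at 2800 nM in this assay, within a range of 900 nM to 9000 nM.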

Compound 4, half-maximal inhibitory concentration: 7750 nM
Compound 4: middle estimate off by 2.8-fold (0.44 log units), on the low side; the measured number falls inside the stated range.
By their numbers in this assay, from the lowest: compounds 3 and 2 (each within the scatter of the next); then compounds 4 and 1 (each within the scatter of the next).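

Exchanging chloro for hydroxy, on an aromatic carbon para to a large group, moves the number beyond the scatter (a 5.7-fold higher number from compound 3 to compound 4 (0.75 log units; beyond the scatter)), so this position is not indifferent to a single-atom change, which the step between the two halogenated compounds could not show. The 4-hydroxyphenyl group also separates from the 2,4-difluorophenyl group (a 4.1-fold higher number from compound 2 to compound 4 (0.61 log units; beyond the scatter)). It cannot, however, be ordered against the 2,4-dimethoxyphenyl group (a 1.6-fold lower number from compound 1 to compound 4 (0.21 log units; within the scatter)), so the four compounds fall into two groups, with the halogen-bearing compound 2 and compound 3 at lower numbers and the oxygen-bearing compound 1 and compound 4 at higher ones, and none of the four goes against this split.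

Whether that split follows the halogens or the oxygen substituents remains open, as the shown series has no 4-methylphenyl or unsubstituted phenyl group to sit between the two, and a 4-aminophenyl or 4-carboxyphenyl group would extend the comparison at the same position. No measurement among those given accounts for the higher numbers of compound 1 and compound 4.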